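The source may hold more compounds than are shown below. What is called first, only, known or untested is meant among the compounds shown, and "the series" means these compounds.

Compound 3 `O=[N+]([O-])c1cc(-c2nnn(CSc3nnnn3-c3ccc(Br)cc3)n2)cc([N+](=O)[O-])c1` gives 29000 nM in an ADME assay on CHO-K1 cells (Cricetulus griseus) for cytotoxicity, read by MTT assay, with a stated time of 24 h (on this read-out lower numbers stand for stronger inhibition and higher numbers for weaker inhibition), the second highest of the three numbers measured: compound 1 `O=[N+]([O-])c1cc(-c2nnn(CSc3nnnn3C3CCCCC3)n2)cc([N+](=O)[O-])c1` gives 140000 nM, and compound 2 `O=[N+]([O-])c1cc(-c2nnn(CSc3nnnn3-c3ccc(Cl)cc3)n2)cc([N+](=O)[O-])c1` gives 14000 nM. Compound 4 `COc1cccc(-n2nnnc2SCn2nnc(-c3cc([N+](=O)[O-])cc([N+](=O)[O-])c3)n2)c1` differs from compound 3 by 3-methoxyphenyl in place of 4-bromophenyl on an aromatic nitrogen. For the measured compounds named here, no measured step swaps one substituted phenyl for another with a different substituent, so the nearest guides are a 2.1-fold higher number from compound 2 to compound 3 (0.32 log units; beyond the scatter), together with a 10-fold lower number from compound 1 to compound 2 (1.00 log units; beyond the scatter) and a 4.8-fold lower number from compound 1 to compound 3 (0.68 log units; beyond the scatter). Those steps were all modest, and swapping one aryl group for another changed the number least, so the account expects a step of a 1.2-fold higher number from compound 3 to compound 4 (0.08 log units; within the scatter), within or only just beyond the scatter. Compound 4 is therefore estimated at 35000 nM in this assay, with a range from 12000 nM to 100000 nM.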

Compound 4, half-maximal inhibitory concentration: 135000 nM
For compound 4 the middle estimate is 3.9-fold (0.59 log units) below the measured one; measured number above the stated range.
By their numbers in this assay, from the lowest: compound 2; then compound 3; then compounds 4 and 1 (each within the scatter of the next).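

In this assay the swap at this aromatic nitrogen shows that one aryl group cannot stand in for another: 3-methoxyphenyl in place of 4-bromophenyl brings a 4.7-fold higher number from compound 3 to compound 4 (0.67 log units; beyond the scatter) and in place of 4-chlorophenyl brings a 9.6-fold higher number from compound 2 to compound 4 (0.98 log units; beyond the scatter) and so loses the lower numbers of both halogen-bearing compounds. An aryl group as such therefore does not give a lower number than cyclohexyl, since 3-methoxyphenyl in place of cyclohexyl brings a 1.0-fold lower number from compound 1 to compound 4 (0.02 log units; within the scatter) and stays within the scatter. Nothing measured here explains this difference. The compounds shown do not separate the methoxy group from its place on the ring, and what a plain phenyl or a benzyl group would give on this nitrogen stays open.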